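Swapping the Aryl Group for a Hydroxy Group

This account rests on a few compounds, and the source may have more. Where it says the series, first, only, none or still open, it means among the compounds named here.

Measured so far:
compound 1 `Clc1ccc(C2C3CCC2CN(Cc2ccccc2)C3)cc1`: 95.5 nM
compound 2 `CN1CC2CCC(C1)C2c1ccccc1`: 360 nM

In an assay on cell membranes from striatum for binding affinity to sodium-dependent dopamine transporter (Rattus norvegicus) (a lower number here means a stronger inhibitor, a higher number a weaker inhibitor), compound 1 gives 95.5 nM, the lower of the two numbers recorded. Compound 2 gives 360 nM, and the gap between the two lies beyond the usual scatter of repeat measurements.

Compound 3 `OC1C2CCC1CN(Cc1ccccc1)C2` has not yet been measured. It differs from compound 1 by hydroxy in place of 4-chlorophenyl on a saturated ring carbon, a hydroxy in place of 4-chlorophenyl on a saturated ring carbon. For the measured compounds named here, no measured pair shows this kind of change, so the expectation rests on the structure alone. The change is expected to weaken binding considerably, with a step of an 84-fold higher number from compound 1 to compound 3 (1.92 log units; beyond the scatter) from compound 1 to compound 3. Compound 3 is therefore estimated at 8000 nM, plausibly between 1500 nM and 50000 nM.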

Compound 3, half-maximal inhibitory concentration: 22100 nM
The estimate for compound 3 lay 2.8-fold (0.44 log units) below the measured number; the range from low to high includes it.
By their numbers in this assay, from the lowest: compound 1; then compound 2; then compound 3.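

This first measured change at this position is a large one: in this assay, hydroxy in place of 4-chlorophenyl on the saturated ring carbon gives a 230-fold higher number from compound 1 to compound 3 (2.36 log units; beyond the scatter). Binding therefore depends strongly on what this carbon carries, and the core of compound 1 with hydroxy here binds only weakly. No measured evidence explains the size of this step.

This single swap cannot show whether the loss of 4-chlorophenyl or the arrival of hydroxy matters more. An unsubstituted phenyl ring, a methoxy group or an amine on the same carbon could help separate these two parts of the change.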